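The compounds below may be only part of what the source reports. "The series", "measured", "known", "first", "only" and "open" are said of these compounds alone.

Measured so far:
compound 1, `C/C=C/C=C/C(=O)N[C@H](C(=O)NCCCCCCCCCCCC)[C@@H](C)O`, 200000 nM
compound 2, `CCCCCCCCCCCCNC(=O)[C@@H](NS(=O)(=O)c1ccc(C)cc1)[C@@H](C)O`, 25600 nM
compound 3, `C/C=C/C=C/C(=O)N[C@H](C(=O)NCCCCCCCCCCCCCCCCCC)[C@@H](C)O`, 200000 nM

All three were tested in a functional assay on SW-620 cells (Homo sapiens) for cytotoxicity, read by MTT assay, with a stated time of 48 h; a lower number here means a stronger inhibitor, a higher number a weaker inhibitor. Compound 1 and compound 3 share one core and differ only in the length of the chain on the amide nitrogen: hexyl in place of hydrogen on a saturated chain carbon, ten or more bonds along the chain from an amide-type nitrogen. That lengthening left the result unchanged, no change at the digits printed from compound 1 to compound 3 (within the scatter), so compound 1 and compound 3 stand level, and together they give the highest numbers of the three.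

Compound 2 is compound 1 with a different group on the amine nitrogen: (4-methylphenyl)sulfonyl in place of (penta-1,3-dien-1-yl)carbonyl on an amine nitrogen. This brought the number down, a 7.8-fold lower number from compound 1 to compound 2 (0.89 log units; beyond the scatter), a modest step but one that lies beyond the usual scatter.

Compound 4, `CCCCCCCCCCCCCCCCCCNC(=O)[C@@H](NS(=O)(=O)c1ccc(C)cc1)[C@@H](C)O`, is not yet measured. Going by the values given here, it carries the same change on the same kind of position as the one between compound 1 and compound 2, now made on compound 3: (4-methylphenyl)sulfonyl in place of (penta-1,3-dien-1-yl)carbonyl on an amine nitrogen. Since lengthening the chain did nothing on its own, the step from compound 3 to compound 4 is expected to be about the size of the step from compound 1 to compound 2, that is a 7.1-fold lower number from compound 3 to compound 4 (0.85 log units; beyond the scatter), resting on compound 1 and compound 2 with a 7.8-fold lower number from compound 1 to compound 2 (0.89 log units; beyond the scatter) and on compound 3 with 200000 nM. Compound 4 is therefore estimated at 28000 nM, expected to fall between 9000 nM and 90000 nM in this assay.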

Compound 4, half-maximal inhibitory concentration: 32500 nM
Beside the measured number, compound 4's estimate is 1.2-fold (0.06 log units) below it, and the stated range covers the measured number.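

In this assay, putting (4-methylphenyl)sulfonyl in place of (penta-1,3-dien-1-yl)carbonyl on the amine nitrogen gives a 6.2-fold lower number from compound 3 to compound 4 (0.79 log units; beyond the scatter), so the change carries over from the core of compound 1 to the core of compound 3 at much the same size: the same change on two cores in this assay, a 7.8-fold lower number (0.89 log units; beyond the scatter) from compound 1 to compound 2 and a 6.2-fold lower number (0.79 log units; beyond the scatter) from compound 3 to compound 4, 1.3-fold (0.10 log units) apart, within the scatter of two such steps

The longer chain on the amide nitrogen, seen in the other direction of the same set of four compounds, gives a 1.3-fold higher number from compound 2 to compound 4 (0.10 log units; within the scatter), which stays within the scatter with the sulfonyl group in place, as it did with the carbonyl group: the same change on two cores in this assay, no change at the digits printed (within the scatter) from compound 1 to compound 3 and a 1.3-fold higher number (0.10 log units; within the scatter) from compound 2 to compound 4, 1.3-fold (0.10 log units) apart, within the scatter of two such steps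

Across these four compounds the two changes therefore behave as if independent of each other, but this rests on one swap, one pair of chain lengths and one cell line, so it is no general rule, and it says nothing about why the sulfonyl group lowers the number.

As far as these compounds go, it remains open whether the same step would appear with other groups on the amine nitrogen, such as a benzoyl or a plain acetyl, or with a chloro group in place of the methyl on the aromatic ring. Also open, from the compounds shown here alone, is whether a much shorter chain on the amide nitrogen, such as butyl, would still leave the result unmoved.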